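This account rests on a few compounds, and the source may have more. Where it says the series, first, only, none or still open, it means among the compounds named here.

Of the compounds shown here, three sharing one core have been measured in a functional assay on HCT-116 cells (Homo sapiens) for inhibition, read by CCK-8 assay, with a stated time of 48 h; a lower number here means a stronger inhibitor, a higher number a weaker inhibitor. Compound 1 `COc1cc(-c2ccnc3cc(-c4c[nH]c5ccccc45)nn23)cc(OC)c1OC` carries a 1H-indol-3-yl group and gives 35 nM. Compound 2 `COc1cc(-c2ccnc3cc(-c4ccc(C)c(C)c4)nn23)cc(OC)c1OC` has a 3,4-dimethylphenyl group in place of it and gives 261 nM, the second highest of the three numbers. Compound 3 `COc1cc(-c2ccnc3cc(-c4cn(C(=O)OC(C)(C)C)c5ccccc45)nn23)cc(OC)c1OC`, in which a tert-butoxycarbonyl replaces the hydrogen on the indole nitrogen, gives 5720 nM. Two steps connect these. Exchanging the indole for the dimethylphenyl brings a 7.5-fold higher number from compound 1 to compound 2 (0.87 log units; beyond the scatter), while capping the indole nitrogen brings a 160-fold higher number from compound 1 to compound 3 (2.21 log units; beyond the scatter).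

Compound 4 `COc1cc(-c2ccnc3cc(-c4ccc5cnn(C)c5c4)nn23)cc(OC)c1OC` is compound 2 with 1-methyl-1H-indazol-6-yl in place of 3,4-dimethylphenyl on an aromatic carbon. The change restores a two-ring aromatic group, which in compound 1 went with the lowest number, but the ring nitrogen of compound 4 carries a methyl rather than a hydrogen, and compound 3 showed a 160-fold higher number from compound 1 to compound 3 (2.21 log units; beyond the scatter) once its nitrogen was substituted. The indazole is also joined through a different ring atom than the indole of compound 1, so neither measured step transfers cleanly. A small move toward the number of compound 1 is expected, of a size that may stay within the scatter: a 2.0-fold lower number from compound 2 to compound 4 (0.30 log units; within the scatter). The estimated value for compound 4 in this assay is 130 nM, with a range from 35 nM to 500 nM.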

Compound 4, half-maximal inhibitory concentration: 2440 nM
Estimate against measurement, compound 4: 19-fold (1.27 log units) below; measured number above the stated range.
By their numbers in this assay, from the lowest: compound 1; then compound 2; then compound 4; then compound 3.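

In this assay, a two-ring aromatic group at this position does not by itself give a low number: 1-methyl-1H-indazol-6-yl in place of 3,4-dimethylphenyl brings a 9.3-fold higher number from compound 2 to compound 4 (0.97 log units; beyond the scatter), and in place of 1H-indol-3-yl it brings a 70-fold higher number from compound 1 to compound 4 (1.84 log units; beyond the scatter), so here the single-ring group of compound 2 does better than this two-ring group. Compound 1 is the only one of the four with a hydrogen on a ring nitrogen, and it has the lowest number, but compound 2 also lacks such a hydrogen and still stands well below compound 4, so that hydrogen alone cannot order the series. No measurement shown here explains why the 1-methyl-1H-indazol-6-yl group gives so much higher a number.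

The compounds shown leave open whether 1H-indazol-6-yl, without the methyl on its nitrogen, would fall nearer compound 1 or stay close to compound 4. Going by these compounds, it is also open where a phenyl ring carrying an amine or a carboxylic acid in place of the two methyl groups would fall.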